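Carboxymethoxy in place of hydroxyethoxy on a weak inhibitor

The source may report more compounds than this note shows. Statements on the series, on what has been measured and on what is new or still open speak of the compounds shown alone.

The account concerns three measured compounds that share a core and one compound not yet measured. Compound 1 `COc1ccc(C(c2ccc(OCCO)cc2)c2cccc3ccccc23)c(OC)c1OC` was tested in a functional assay on MDA-MB-231 cells (Homo sapiens) for inhibition, read by sulforhodamine B assay, with a stated time of 48 h; a higher number here means a weaker inhibitor, a lower number a stronger inhibitor. In this assay compound 1 gives > 20000 nM, which is a limit of the assay and not a number. Compound 2 `CCOC(=O)C(C)C(O)(c1ccc(OC)c(OC)c1OC)c1cccc2ccccc12` gives in this assay > 20000 nM, likewise a limit of the assay. Compound 3 `C=C(c1ccc(OC)c(OC)c1OC)c1cccc2ccccc12` gives in this assay 4660 nM. Compound 1 therefore stands at the limit of > 20000 nM in this assay, at which 2 of the 3 values shown sit, and it shows no number of its own within the range of the assay.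

Compound 4 `COc1ccc(C(c2ccc(OCC(=O)O)cc2)c2cccc3ccccc23)c(OC)c1OC` differs from compound 1 in one place: carboxy in place of hydroxymethyl on a saturated chain carbon bound to an oxygen on an aromatic ring. No step between measured compounds is shown, so the data give no direction for this change. Compound 4 is expected to stay near the limit, with an estimated value in this assay of 25000 nM, between 8000 nM and 80000 nM. The step expected from compound 1 to compound 4 is a step that the limit leaves unreadable from compound 1 to compound 4, within the scatter.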

Compound 4, half-maximal inhibitory concentration: > 20000 nM
Compound 4 ended at the assay's limit (the forecaster's own chance of this, stated with the estimate: 70%); the middle value does not contradict the limit.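

Compound 1 and compound 4 both stand at a limit of this assay, so no step between them can be read: the limit of > 20000 nM in this assay, at which 3 of the 4 values shown sit.

The compounds shown leave open how 2-hydroxyethoxy and carboxymethoxy compare on the shared core in this assay.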